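Cyanopyridone Modulators of Metabotropic Glutamate Receptor 2: Aryl Variation

The source may report more compounds than this note shows. Statements on the series, on what has been measured and on what is new or still open speak of the compounds shown alone.

Compound 1: `N#Cc1c(N2CCC(c3ccccc3)CC2)ccn(CC2CC2)c1=O` — 151 nM
Compound 2: `N#Cc1c(N2CCC(c3ccccc3Cl)CC2)ccn(CC2CC2)c1=O` — 49 nM

In a functional assay on CHO cells for positive allosteric modulation of metabotropic glutamate receptor 2 (Homo sapiens), with a stated time of 30 min (on this read-out lower numbers stand for an effect already at smaller amounts and higher numbers for an effect only at larger amounts of compound), compound 1 gives 151 nM, and compound 2 gives 49 nM. Among the compounds with values here, the change a 3.1-fold lower number from compound 1 to compound 2 (0.49 log units; beyond the scatter) is the only measured step, and it places compound 2 at the lowest number of the two, with compound 1 as its nearest neighbour.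

Compound 3, `N#Cc1c(N2CCC(c3cc(F)cc(F)c3)CC2)ccn(CC2CC2)c1=O`, is not yet measured. Its change from compound 2 is 3,5-difluorophenyl in place of 2-chlorophenyl on a saturated ring carbon. Within the data shown here, no measured step covers this exact exchange; the step from compound 1 to compound 2 shows only that a halogen on the phenyl ring can shift the number, and it gives no guidance on two fluorines at the 3,5-positions. Compound 3 is therefore expected to land near the measured pair, with the step of a 1.6-fold higher number from compound 2 to compound 3 (0.21 log units; within the scatter) estimated as small. The estimate for compound 3 is 80 nM, within a range from 25 nM to 250 nM.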

Compound 3, half-maximal effective concentration: 151 nM
Estimate against measurement, compound 3: 1.9-fold (0.28 log units) below, and the stated range covers the measured number.
By their numbers in this assay, from the lowest: compound 2; then compounds 1 and 3 (each within the scatter of the next).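

In this assay, a halogenated phenyl group does not by itself lower the number: 3,5-difluorophenyl in place of phenyl gives no change at the digits printed from compound 1 to compound 3 (within the scatter), whereas 3,5-difluorophenyl in place of 2-chlorophenyl gives a 3.1-fold higher number from compound 2 to compound 3 (0.49 log units; beyond the scatter). At this saturated ring carbon, then, the lower number seen with 2-chlorophenyl does not extend to every halogenated phenyl group, and among the three compounds only compound 2 stands apart. Nothing measured here accounts for the difference between these aryl groups.

As far as these compounds go, whether the lower number of compound 2 goes with the chlorine itself or with the position it holds on the phenyl ring remains open. Also open, from the compounds shown here alone, is what a methoxy group or an amine on that ring would do to the number.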